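Propyl in Place of Methylsulfanyl on the Shared Core

The source may hold more compounds than are shown below. What is called first, only, known or untested is meant among the compounds shown, and "the series" means these compounds.

Of the compounds shown here, three with a shared core have been tested in a functional assay on the whole organism for activation, with Mus musculus as the target; a higher number here means that more compound is needed for the effect, a lower number that less compound is needed. Compound 2 `CSc1nc(N)c2nc(O)n(Cc3ccccc3)c2n1` gives 0.1 mg/kg, the lowest number of the three. Compound 1 `CCCCCNc1nc(N)c2nc(O)n(Cc3ccccc3)c2n1` gives 0.3 mg/kg, and compound 3 `Nc1ncnc2c1nc(O)n2Cc1ccccc1` gives 30 mg/kg. Compound 4 `CCCc1nc(N)c2nc(O)n(Cc3ccccc3)c2n1` has not yet been measured in this assay; it differs from compound 2 in one place: propyl in place of methylsulfanyl on an aromatic carbon.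

Among the compounds with values here, two measured steps bear on this change. The step of a 300-fold higher number from compound 2 to compound 3 (2.48 log units; beyond the scatter) is large and shows that removing the group at this position altogether costs a great deal. The step of a 3.0-fold lower number from compound 1 to compound 2 (0.48 log units; beyond the scatter) is modest and shows that swapping one substituent at this position for another of a different kind shifts the number only a little. Propyl keeps a substituent at the position, so the outcome is expected to lie close to compound 2 and compound 1, with at most a modest step in this assay, most likely towards a higher number, as seen from compound 2 to compound 1. Compound 4 is therefore estimated at 0.3 mg/kg, with a range from 0.1 mg/kg to 1 mg/kg, meaning an expected step of a 3.0-fold higher number from compound 2 to compound 4 (0.48 log units; beyond the scatter).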

Compound 4, minimum effective dose: 3 mg/kg
The estimate for compound 4 lay 10-fold (1.00 log units) below the measured number; the measured number lies above the stated range.
By their numbers in this assay, from the lowest: compound 2; then compound 1; then compound 4; then compound 3.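

In this assay, within the data shown here, a 30-fold higher number from compound 2 to compound 4 (1.48 log units; beyond the scatter) shows that keeping a substituent at this aromatic carbon is not enough to hold the number near that of compound 2, so the nature of the group matters more than the earlier compounds showed. Propyl recovers only part of what is lost with hydrogen, as a 10-fold lower number from compound 3 to compound 4 (1.00 log units; beyond the scatter) shows, while a 10-fold higher number from compound 1 to compound 4 (1.00 log units; beyond the scatter) leaves it behind pentylamino, so among these compounds the two groups attached through sulfur or nitrogen give lower numbers than the all-carbon propyl. Nothing available explains this difference.

The compounds shown leave open whether the attaching atom or the chain length matters more. A propylsulfanyl, propylamino or pentyl group at this position would separate the two.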